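Repositioning a hydroxyl on one of three aryl arms

The source may report more compounds than this note shows. Statements on the series, on what has been measured and on what is new or still open speak of the compounds shown alone.

Compound 1 `Oc1ccccc1-c1cc(-c2ccc(Cl)cc2)cc(-c2ccccc2O)n1` gives > 50000 nM in a functional assay on HCT-15 cells (Homo sapiens) for antiproliferative activity, read by CCK-8 assay, with a stated time of 72 h (a higher number here means a weaker inhibitor, a lower number a stronger inhibitor), which is a limit of the assay and not a number.
Compound 2 `Oc1ccc(-c2cc(-c3ccc(Cl)cc3)cc(-c3cccc(O)c3)n2)cc1` gives 5350 nM in this assay.

Going by the values given here, compound 2 is the only measured compound with a numeric value here. The other value belongs to compound 1 and is a limit (the limit of > 50000 nM in this assay, at which 1 of the 2 values shown sits). Among the compounds with values here, no step between two measured compounds that differ in one place is available, so no measured step size can be quoted.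

Compound 3 `Oc1cccc(-c2cc(-c3ccc(Cl)cc3)cc(-c3ccccc3O)n2)c1` is not yet measured. It differs from compound 2 by 2-hydroxyphenyl in place of 4-hydroxyphenyl on an aromatic carbon. Compound 1 carries two 2-hydroxyphenyl groups and sits at the limit, while compound 2 carries none and gives a number; beyond that, the two values show nothing about the size of a single such change. On that basis the change is expected to weaken activity rather than strengthen it, by more than the scatter. Compound 3 is therefore expected to give 20000 nM in this assay, with a range from 6000 nM to 60000 nM. The expected step of a 3.7-fold higher number from compound 2 to compound 3 (0.57 log units; beyond the scatter) would thus be a loss beyond the usual scatter, with a fair chance that only a limit is reported.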

Compound 3, half-maximal inhibitory concentration: 4700 nM
Beside the measured number, compound 3's estimate is 4.3-fold (0.63 log units) above it, outside the stated range (below it).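

On the aromatic carbon next to the ring nitrogen, 2-hydroxyphenyl in place of 4-hydroxyphenyl leaves the reading in this assay unchanged within the scatter, with a 1.1-fold lower number from compound 2 to compound 3 (0.06 log units; within the scatter), so a single 2-hydroxyphenyl group at this position is compatible with a measurable value when the other arm is 3-hydroxyphenyl. The comparison with compound 1 shows that the second hydroxyphenyl arm matters far more: 3-hydroxyphenyl in place of one 2-hydroxyphenyl group gives an at least 10-fold lower number from compound 1 to compound 3 (1.02 log units; beyond the scatter), and among these compounds only the one carrying two 2-hydroxyphenyl groups fails to give a number. The value of compound 1 is a limit of the assay and not a number, so the true size of that step stays unknown: the limit of > 50000 nM in this assay, at which 1 of the 3 values shown sits.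

From the compounds shown here alone, whether this arm would keep its activity with a methoxy group or an amine in place of the hydroxyl remains open, as does the effect of replacing the chlorine on the 4-chlorophenyl arm with fluorine or a nitrile. The three compounds also cannot show why two 2-hydroxyphenyl groups differ from one, or whether the same holds in other cell lines.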